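A few compounds are considered here, and "the series" means these few. Any claim that something is new, unique, unknown or untested is made for them only; others in the source may bear on it.

Compound 1 `CC(C)Nc1nc(NCc2ccco2)c2cccc(Cl)c2n1` and compound 2 `CC(C)Nc1nc(NCc2ccco2)c2ccc(Cl)cc2n1` are built from the same atoms joined differently; the difference between the two cores is not broken down here. In a physicochemical assay for permeability, using PAMPA, at pH 7.4 (on this read-out lower numbers stand for lower permeability and higher numbers for higher permeability), compound 1 gives 1330 10^-6 cm/s, and in this assay compound 2 gives 1380 10^-6 cm/s, two numbers that lie within the usual scatter of each other. Compound 3 `Cc1cccc2c(NCc3ccco3)nc(NC(C)C)nc12` arises from compound 1 through methyl in place of chloro on an aromatic carbon and in this assay compound 3 gives 666 10^-6 cm/s, so that the recorded step is a 2.0-fold lower number from compound 1 to compound 3 (0.30 log units; within the scatter).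

Compound 4 `Cc1ccc2c(NCc3ccco3)nc(NC(C)C)nc2c1` has not yet been measured. For the measured compounds named here, it differs from compound 2 by methyl in place of chloro on an aromatic carbon, the same kind of change as the one that leads from compound 1 to compound 3, but not the same: in compound 3 the methyl stands ortho to a fused ring and meta to a fused ring, whereas in compound 4 it stands meta to a fused ring and para to a fused ring. Going by the values given here, only one instance of this kind of change has been measured, and it rests on compound 1 and compound 3 alone. On that footing compound 4 is expected to show a step of a 2.0-fold lower number from compound 2 to compound 4 (0.29 log units; within the scatter) in this assay, close in size to a 2.0-fold lower number from compound 1 to compound 3 (0.30 log units; within the scatter). Compound 4 is accordingly estimated at 700 10^-6 cm/s, with a range from 400 10^-6 cm/s to 1250 10^-6 cm/s that allows for the scatter and for the change sitting at a different place on the core.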

Compound 4, apparent permeability: 798 10^-6 cm/s
The estimate for compound 4 lay 1.1-fold (0.06 log units) below the measured number; low and high end bracket the measured number.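

In this assay the step of a 1.7-fold lower number from compound 2 to compound 4 (0.24 log units; within the scatter) stands alongside a 2.0-fold lower number from compound 1 to compound 3 (0.30 log units; within the scatter) and is of much the same size, so methyl in place of chloro on an aromatic carbon reads alike on the two cores, even with the change at a different place on each. Both steps lie within the usual scatter, so the pair shows agreement between two cores but does not establish that the change itself moves this read-out, and two instances give no rule for other cores or for other places on the ring. Nothing measured here speaks to what lies behind these numbers.

The compounds shown leave open how far this agreement extends beyond the swap of chloro for methyl, for instance whether a methoxy group, a nitrile or a trifluoromethyl group on the same aromatic carbons would also read alike on the two cores. They also leave open what a strongly ionisable group such as a carboxylic acid or a primary amine would do at these places in this assay.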